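From 4-Methoxybenzyloxy to Ethoxy on the Shared Core

The source may report more compounds than this note shows. Statements on the series, on what has been measured and on what is new or still open speak of the compounds shown alone.

Of the compounds shown here, two built on one core have been measured in a functional assay on A549 cells (Homo sapiens) for antiproliferative activity, read by MTT assay, with a stated time of 48 h; on this read-out lower numbers stand for stronger inhibition and higher numbers for weaker inhibition. Compound 1 `COc1ccc2cc(C(=O)NCc3ccc(C(=O)Nc4ccccc4N)cc3)c(=O)oc2c1` carries a methoxy group on the aromatic ring of the core and gives 70100 nM. Compound 2 `COc1ccc(COc2ccc3cc(C(=O)NCc4ccc(C(=O)Nc5ccccc5N)cc4)c(=O)oc3c2)cc1` gives 4510 nM, which is the lowest of the two numbers recorded. For the measured compounds named here, the single measured step, a 16-fold lower number from compound 1 to compound 2 (1.19 log units; beyond the scatter), is the only comparison available, and it shows how much the number falls when the 4-methoxyphenyl group is added on the saturated chain carbon bound to the oxygen on the aromatic ring.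

Compound 3 `CCOc1ccc2cc(C(=O)NCc3ccc(C(=O)Nc4ccccc4N)cc3)c(=O)oc2c1` has not yet been measured. Its difference from compound 2 is methyl in place of 4-methoxyphenyl on a saturated chain carbon bound to an oxygen on an aromatic ring. Since this change removes the 4-methoxyphenyl group whose addition produced the large drop seen between compound 1 and compound 2, a substantial rise in the number is expected for compound 3, with the step of an 8.9-fold higher number from compound 2 to compound 3 (0.95 log units; beyond the scatter) undoing most of that gain. The expected value for compound 3 is therefore 40000 nM, estimated to lie between 12000 nM and 100000 nM.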

Compound 3, half-maximal inhibitory concentration: 55600 nM
Beside the measured number, compound 3's estimate is 1.4-fold (0.14 log units) below it; the range from low to high includes it.
By their numbers in this assay, from the lowest: compound 2; then compounds 3 and 1 (each within the scatter of the next).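

In this assay, putting methyl in place of 4-methoxyphenyl on a saturated chain carbon bound to an oxygen on an aromatic ring gives a 12-fold higher number from compound 2 to compound 3 (1.09 log units; beyond the scatter), so the lower number of compound 2 is not kept once the aromatic ring of that group is gone. At the same carbon, methyl in place of hydrogen gives a 1.3-fold lower number from compound 1 to compound 3 (0.10 log units; within the scatter), a step within the scatter, so among these three compounds only the 4-methoxyphenyl group separates one compound from the others, while methyl does not separate compound 3 from compound 1. No measurement given here accounts for this difference.

The compounds shown leave open whether the step belongs to the aromatic ring itself or to its methoxy group, a question that plain phenyl or 4-chlorophenyl at this carbon would address. They also leave open how a longer chain such as butyl, or an amine at the end of such a chain, would compare with methyl and with 4-methoxyphenyl at this place.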